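Swapping trifluoromethyl for acetamido in compound 3

This account rests on a few compounds, and the source may have more. Where it says the series, first, only, none or still open, it means among the compounds named here.

Compound 1 `O=C1/C(=C/c2ccncc2)CN(S(=O)(=O)c2ccc(C(F)(F)F)cc2)C/C1=C\c1ccccc1F`: 9500 nM
Compound 2 `O=C1/C(=C/c2cccnc2)CN(S(=O)(=O)c2ccc(C(F)(F)F)cc2)C/C1=C\c1ccccc1C(F)(F)F`: 1500 nM
Compound 3 `O=C1/C(=C/c2ccncc2)CN(S(=O)(=O)c2ccc(C(F)(F)F)cc2)C/C1=C\c1ccccc1C(F)(F)F`: 4680 nM

All three compounds were tested in a functional assay on QGY-7703 cells (Homo sapiens) for cytotoxicity, read by MTT assay, with a stated time of 24 h; a higher number here means a weaker inhibitor, a lower number a stronger inhibitor. Compound 3, at 4680 nM, holds the middle place of the three numbers, with compound 1 higher and compound 2 lower.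

The next compound, compound 4 `CC(=O)Nc1ccc(S(=O)(=O)N2C/C(=C\c3ccncc3)C(=O)/C(=C/c3ccccc3C(F)(F)F)C2)cc1`, keeps the shared core and changes one group: acetamido in place of trifluoromethyl on an aromatic carbon, para to a large group (acetamido in place of trifluoromethyl on an aromatic carbon).

Among the measured compounds shown here, no measured compound carries acetamido, and neither measured step touches this spot, so the evidence is only indirect. Trifluoromethyl in place of fluoro on a different aromatic carbon gave a 2.0-fold lower number from compound 1 to compound 3 (0.31 log units; beyond the scatter). Pyridin-4-yl in place of pyridin-3-yl gave a 3.1-fold higher number from compound 2 to compound 3 (0.49 log units; beyond the scatter). Both steps are modest, though beyond the scatter, and they offer only a rough guide to size. Neither gives a direction for the new group.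

A step of similar modest size at most is therefore expected in this assay, with its direction open. The estimated step is a 1.2-fold higher number from compound 3 to compound 4 (0.07 log units; within the scatter). For compound 4, the expected value is about 5500 nM, with an estimated range from 2000 nM to 15000 nM.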

Compound 4, half-maximal inhibitory concentration: 5560 nM
The estimate for compound 4 lay 1.0-fold (0.00 log units) below the measured number; the range from low to high includes it.
By their numbers in this assay, from the lowest: compound 2; then compounds 3, 4 and 1 (each within the scatter of the next, the first and the last beyond it).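

The earlier compounds shown here all carried trifluoromethyl on the aromatic carbon para to a large group, so they could say nothing about this position. Compound 4 gives the first reading there. In this assay, acetamido in place of trifluoromethyl gives a 1.2-fold higher number from compound 3 to compound 4 (0.07 log units; within the scatter), so the two groups cannot be told apart in this assay, even though acetamido adds a hydrogen-bond donor and a hydrogen-bond acceptor where trifluoromethyl counts neither. Nothing available explains why the swap leaves the result within the scatter.

Among the compounds shown here, compounds 3 and 4 cover only two groups at this position, so it remains open whether an amine, a carboxylic acid or a longer chain in the same place would also stay within the scatter of compound 3 or move clearly away from it. As far as these compounds go, it is also open whether acetamido would behave the same way alongside the pyridin-3-yl group of compound 2, which gives 1500 nM with trifluoromethyl at this position.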